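A few compounds are considered here, and "the series" means these few. Any claim that something is new, unique, unknown or untested is made for them only; others in the source may bear on it.

Compound 3 `CN(C)C(=O)c1cc2cnc(Nc3ccc(NC(=O)CCCCCCN=C=S)cc3)nc2n1C1CCCC1` gives 80.9% in a functional assay on NCI-H1299 cells (Homo sapiens) for inhibition, read by CCK-8 assay, with a stated time of 72 h, tested at 10 uM (a higher number here means a stronger effect of the compound at the concentration tested, a lower number a weaker effect), the highest of the three numbers measured, while compound 2 `CN(C)C(=O)c1cc2cnc(Nc3ccc(C(=O)NCCCCCN=C=S)cc3)nc2n1C1CCCC1` gives 76.5% and compound 1 `CN(C)C(=O)c1cc2cnc(Nc3ccc(S(=O)(=O)NCCCCN=C=S)cc3)nc2n1C1CCCC1` gives 72.7%. The steps of a number 4.4 percentage points higher from compound 2 to compound 3 (within the scatter) and a number 8.2 percentage points higher from compound 1 to compound 3 (within the scatter) both stay within the scatter, as does a number 3.8 percentage points higher from compound 1 to compound 2 (within the scatter). Compound 4 `CN(C)C(=O)c1cc2cnc(Nc3ccc(N=C=S)cc3)nc2n1C1CCCC1` differs from compound 3 by a group of 3 heavy atoms (1 carbon, 1 nitrogen, 1 sulfur; no ring) in place of a group of 12 heavy atoms (8 carbon, 2 nitrogen, 1 oxygen, 1 sulfur; no ring), on an aromatic carbon. Every measured step swaps one long chain for another of similar length, and none removes the chain altogether, so they bear only loosely on this change; what they do show is that altering the chain moved this assay little. The expected step of a number 8.9 percentage points lower from compound 3 to compound 4 (within the scatter) is therefore small, with wide uncertainty. Compound 4 is expected to give about 72%, estimated between 50% and 88%.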

Compound 4, a percentage reported as inhibition, at one concentration (the size of the read-out at that concentration, not a potency): 83.7%
For compound 4 the middle estimate is 11.7 percentage points below the measured one, and the stated range covers the measured number.
By their numbers in this assay, from the lowest: compounds 1, 2, 3 and 4 (each within the scatter of the next, the first and the last beyond it).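

In this assay, the long chain on this aromatic carbon can be removed altogether, leaving only the group of 3 heavy atoms, and the inhibition remains. The steps of a number 2.8 percentage points higher from compound 3 to compound 4 (within the scatter) and a number 7.2 percentage points higher from compound 2 to compound 4 (within the scatter) show no real difference, while a number 11 percentage points higher from compound 1 to compound 4 (beyond the scatter) is a modest gain over the sulfonamide-linked compound. Among these compounds, then, a long chain at this place is not needed for this read-out at the concentration tested.

Going by these compounds, whether the group of 3 heavy atoms itself matters remains open, as an amine on the same carbon would test. Nothing available gives a cause for these steps.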